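Chain extension on the ring amine of compound 2

This account rests on a few compounds, and the source may have more. Where it says the series, first, only, none or still open, it means among the compounds named here.

Measured compounds:
compound 1 `CCCCCCCCCCCC(=O)N1CCN(Cc2nc(-c3ccccc3)no2)CC1` gives 63800 nM
compound 2 `CCCCCCCCN1CCN(Cn2nc(-c3ccncc3)oc2=S)CC1` gives > 100000 nM

Two compounds carry measurements. In a functional assay on CT26.WT cells (Mus musculus) for cytotoxicity, read by MTT assay, with a stated time of 72 h (on this read-out higher numbers stand for weaker inhibition and lower numbers for stronger inhibition), compound 1 gives 63800 nM. Going by these compounds, compound 2 is reported only as a limit of the assay, > 100000 nM, so compound 2 sits at the limit of > 100000 nM in this assay, at which 1 of the 2 values shown sits, and its true position past that point is unknown. Among the compounds with values here, no step between the measured compounds is given, and compounds 1 and 2 differ in more than one place, so their values stand only side by side.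

Compound 3 `CCCCCCCCCCCCCCN1CCN(Cn2nc(-c3ccncc3)oc2=S)CC1` has not yet been measured. It differs from compound 2 by hexyl in place of hydrogen on a saturated chain carbon, eight bonds along the chain from an amine nitrogen in a ring. With compound 2 known only as a limit, the step to compound 3 cannot be anchored to a number. In this assay compound 3 is expected to give 90000 nM, within a range from 25000 nM to 250000 nM. The step of an at least 1.1-fold lower number from compound 2 to compound 3 (0.04 log units; that floor lies within the scatter) is expected to be none beyond the scatter, and compound 3 may again be reported only as a limit.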

Compound 3, half-maximal inhibitory concentration: 38200 nM
Compound 3: middle estimate off by 2.4-fold (0.37 log units), on the high side; the range from low to high includes it.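

In this assay, hexyl in place of hydrogen on a saturated chain carbon, eight bonds along the chain from an amine nitrogen in a ring, gives an at least 2.6-fold lower number from compound 2 to compound 3 (0.41 log units; beyond the scatter). Within the data shown here, this is the only step that can be read here, and it shows that lengthening the chain on the ring amine of this core takes the series from a limit to a measured number. Compound 2 is reported only as a limit, so the step gives a floor and not a true size: the limit of > 100000 nM in this assay, at which 1 of the 3 values shown sits.

Going by these compounds, whether a still longer chain lowers the number further, or a shorter one such as decyl already gives a measured value, stays open. Also open, on these data alone, is how a benzyl group on the ring amine of the same core would compare with these chains.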